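This account rests on a few compounds, and the source may have more. Where it says the series, first, only, none or still open, it means among the compounds named here.

Compound 1, `CN(C)C1(Cc2ccccc2)CCN(c2cc(C(F)(F)F)ccc2CNC(=O)Nc2ccc(CNS(N)(=O)=O)c(F)c2)CC1`, gives 120 nM in an assay on CHO cells for antagonist activity at transient receptor potential cation channel subfamily V member 1 (Homo sapiens), read by scintillation counting, with a stated time of 5 min, in the presence of a further agent that is not named here; a higher number here means that more compound is needed for the effect, a lower number that less compound is needed. Compound 2, `CN(C)C1(Cc2ccccc2)CCN(c2cc(C(F)(F)F)ccc2CNC(=O)Nc2ccc(CO)c(F)c2)CC1`, gives 81 nM in this assay.

Compound 2 stands at the lower of the two numbers, but the step of a 1.5-fold lower number from compound 1 to compound 2 (0.17 log units; within the scatter) lies within the scatter, so the two compounds cannot be told apart on these data. Compound 3, `CN(C)C1(Cc2ccccc2)CCN(c2cc(C(F)(F)F)ccc2CNC(=O)Nc2cccc3ccc(O)cc23)CC1`, has not yet been measured; it differs from compound 2 by 7-hydroxynaphthalen-1-yl in place of 3-fluoro-4-(hydroxymethyl)phenyl on an amide-type nitrogen. For the measured compounds named here, the only measured step swapped one group on that same ring for another and left the number within the scatter; it offers no guide to exchanging the whole ring for a two-ring group, as happens here. Going by the values given here, with no step of that kind to lean on, compound 2 is the sole anchor, and the expected change is a 1.0-fold lower number from compound 2 to compound 3 (0.01 log units; within the scatter), that is, none beyond the scatter, with wide room either way. Compound 3 is therefore estimated at 80 nM, between 20 nM and 320 nM.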

Compound 3, half-maximal effective concentration: 8.9 nM
The estimate for compound 3 lay 9.0-fold (0.95 log units) above the measured number; measured number outside the range, below it.
By their numbers in this assay, from the lowest: compound 3; then compounds 2 and 1 (each within the scatter of the next).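

This position responds to the aromatic group as a whole: in this assay, the exchange of 3-fluoro-4-(hydroxymethyl)phenyl for 7-hydroxynaphthalen-1-yl on the amide-type nitrogen gives a 9.1-fold lower number from compound 2 to compound 3 (0.96 log units; beyond the scatter), a clearer change than any seen before. The two groups have the same counts of hydrogen-bond donors and acceptors, but the entering group has two six-membered aromatic rings where the leaving group has one. No measurement here explains why the number changes.

The compounds shown do not separate the contribution of the second ring from that of the hydroxy group on it; a naphthalen-1-yl group with no hydroxy, or with a methoxy group or an amine in its place, would address this. On these data alone, it also remains open whether this gain carries over when the dimethylamino group on the shared core is replaced.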